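This account rests on a few compounds, and the source may have more. Where it says the series, first, only, none or still open, it means among the compounds named here.

Two compounds share a core, and both have been tested in a functional assay on Shh Light II cells (Mus musculus) for inhibition, read by a luciferase reporter; a lower number here means a stronger inhibitor, a higher number a weaker inhibitor. Compound 1 `O=C(NCC1CCC1)N1CCC(c2nc(-c3ccc4ccccc4n3)no2)CC1` gives 410 nM. Among the measured compounds shown here, compound 2 `N#Cc1ccccc1NC(=O)N1CCC(c2nc(-c3ccc4ccccc4n3)no2)CC1` gives 190 nM, the lowest of the two numbers; its only neighbour is compound 1, and the step of a 2.2-fold lower number from compound 1 to compound 2 (0.33 log units; beyond the scatter) is beyond the usual scatter. Compound 3 `O=C(Nc1cccnc1Cl)N1CCC(c2nc(-c3ccc4ccccc4n3)no2)CC1` has not yet been measured. It differs from compound 2 in one place: 2-chloropyridin-3-yl in place of 2-cyanophenyl on an amide-type nitrogen. For the measured compounds named here, only one measured step touches the same amide-type nitrogen, a 2.2-fold lower number from compound 1 to compound 2 (0.33 log units; beyond the scatter), and it exchanged cyclobutylmethyl for 2-cyanophenyl, a different kind of change from swapping 2-cyanophenyl for 2-chloropyridin-3-yl. Going by the values given here, no measured pair shows what this exchange does. Both groups are six-membered aromatic rings carrying one hydrogen-bond acceptor, and their counted sizes are close, so the outcome is read cautiously: a small shift, probably within the scatter or at most a modest weakening, is expected. Compound 3 is estimated at 270 nM, with a range from 100 nM to 750 nM. That estimate means an expected step of a 1.4-fold higher number from compound 2 to compound 3 (0.15 log units; within the scatter).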

Compound 3, half-maximal inhibitory concentration: 1600 nM
The estimate for compound 3 lay 5.9-fold (0.77 log units) below the measured number, outside the stated range (above it).
By their numbers in this assay, from the lowest: compound 2; then compound 1; then compound 3.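

In this assay, the group on the amide-type nitrogen turns out to matter well beyond simply being aromatic: 2-chloropyridin-3-yl in place of 2-cyanophenyl gives an 8.4-fold higher number from compound 2 to compound 3 (0.93 log units; beyond the scatter), although both are six-membered aromatic rings with matching counts of hydrogen-bond donors and acceptors and similar heavy-atom counts. The two aromatic groups also fall on opposite sides of the non-aromatic cyclobutylmethyl, since 2-cyanophenyl gave a 2.2-fold lower number from compound 1 to compound 2 (0.33 log units; beyond the scatter), whereas 2-chloropyridin-3-yl gives a 3.9-fold higher number from compound 1 to compound 3 (0.59 log units; beyond the scatter), so among these compounds an aromatic ring at this position does not by itself bring a lower number. Nothing measured on these compounds points to what lies behind the difference.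

This single exchange alters two things at once, the ring atoms and the substituent on the ring, so the compounds shown cannot say whether the pyridine nitrogen, the chlorine or the loss of the nitrile accounts for the higher number. A 2-chlorophenyl group on the same nitrogen would separate these, as its ring is all carbon and it carries the chlorine.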